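A few compounds are considered here, and "the series" means these few. Any claim that something is new, unique, unknown or untested is made for them only; others in the source may bear on it.

Compound 1 `N#CC1=C(N)Oc2c(c3nc4ccccc4nc3c3ccccc23)C12C(=O)N(Cc1cnnn1-c1ccccc1Br)c1ccccc12` belongs to a small series built on one shared core, in which only the aromatic group on an aromatic nitrogen of the five-membered ring with three nitrogens varies. Its effect on cell growth was measured in a functional assay on A549 cells (Homo sapiens) for antiproliferative activity, read by MTT assay, with a stated time of 48 h; on this read-out lower numbers stand for stronger inhibition and higher numbers for weaker inhibition. In this assay compound 1 gives > 50000 nM, which is a limit of the assay and not a number. Compound 2 `N#CC1=C(N)Oc2c(c3nc4ccccc4nc3c3ccccc23)C12C(=O)N(Cc1cnnn1-c1ccc(S(N)(=O)=O)cc1)c1ccccc12` carries a 4-sulfamoylphenyl instead; in this assay compound 2 gives > 50000 nM, again a limit. Compound 3 `Cc1ccc(-n2nncc2CN2C(=O)C3(C(C#N)=C(N)Oc4c3c3nc5ccccc5nc3c3ccccc43)c3ccccc32)cc1C` carries a 3,4-dimethylphenyl; in this assay compound 3 gives > 50000 nM, also a limit. Hence the steps a step that the two limits leave unreadable from compound 1 to compound 2, a step that the two limits leave unreadable from compound 1 to compound 3 and a step that the two limits leave unreadable from compound 2 to compound 3 cannot be sized; all that is known is the limit of > 50000 nM in this assay, at which 3 of the 3 values shown sit.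

Compound 4 `Cc1ccc(C)c(-n2nncc2CN2C(=O)C3(C(C#N)=C(N)Oc4c3c3nc5ccccc5nc3c3ccccc43)c3ccccc32)c1` differs from compound 1 by 2,5-dimethylphenyl in place of 2-bromophenyl on an aromatic nitrogen. The closest measured comparison is compound 3, where another dimethylphenyl also left the value at the limit. Among the compounds with values here, no measured step gives a readable size, so the expectation is that compound 4 stays where the rest of the series sits, with the step that the limit leaves unreadable from compound 1 to compound 4 expected to show no change beyond the scatter. Compound 4 is estimated at 60000 nM, within a range from 30000 nM to 150000 nM, and most likely reported once more only as a limit.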

Compound 4, half-maximal inhibitory concentration: > 50000 nM
Compound 4: a limit, no number (the forecaster's own chance of this, stated with the estimate: 85%); the middle value does not contradict the limit.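

Compound 4 gives only a limit, as do compound 1, compound 2 and compound 3, so no step among these four compounds can be read: the limit of > 50000 nM in this assay, at which 4 of the 4 values shown sit.

The compounds shown leave open how these four aromatic groups rank against one another in this assay, and whether any aromatic group at this place on the shared core would give a readable number.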